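A Cyanobenzyl Swap on the Permeability Series

A few compounds are considered here, and "the series" means these few. Any claim that something is new, unique, unknown or untested is made for them only; others in the source may bear on it.

Compound 3 `COc1cccc(Oc2ccc3c(NCCCNCc4ccco4)ccnc3c2)c1` gives 317 10^-6 cm/s in an ADME assay for permeability, using PAMPA, with a stated time of 30 min, at pH 7.4 (on this read-out higher numbers stand for higher permeability and lower numbers for lower permeability), the same reading at the digits shown as compound 1 `COc1ccccc1Oc1ccc2c(NCCCNCc3ccco3)ccnc2c1`, which gives 317 10^-6 cm/s; together they carry the highest numbers of the three measured here, while compound 2 `COc1ccc(F)cc1CNCCCNc1ccnc2cc(Cc3ccc(C#N)cc3)ccc12` gives 23 10^-6 cm/s, the lowest. For the measured compounds named here, the only single-point step recorded, no change at the digits printed from compound 1 to compound 3 (within the scatter), moves the methoxy group round the phenoxy ring and leaves the reading unchanged within the scatter.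

Compound 4 `N#Cc1ccc(Cc2ccc3c(NCCCNCc4ccco4)ccnc3c2)cc1` differs from compound 3 by 4-cyanobenzyl in place of 3-methoxyphenoxy on an aromatic carbon. Going by the values given here, no recorded step changes the substituent on that aromatic carbon, so the recorded step from compound 1 to compound 3 bears on it only by showing that the phenoxy part tolerates a shift without effect. Compound 2, which also carries a 4-cyanobenzyl group, gives 23 10^-6 cm/s, well below compound 3 in this assay. On that basis compound 4 is expected to fall by a 4.0-fold lower number from compound 3 to compound 4 (0.60 log units; beyond the scatter) relative to compound 3. Compound 4 is estimated at 80 10^-6 cm/s, within a range of 25 10^-6 cm/s to 250 10^-6 cm/s.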

Compound 4, apparent permeability: 23 10^-6 cm/s
Compound 4: the middle estimate sits 3.5-fold (0.54 log units) above what was measured, outside the stated range (below it).
By their numbers in this assay, from the lowest: compounds 2 and 4 (each within the scatter of the next); then compounds 1 and 3 (each within the scatter of the next).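

At this aromatic carbon the swap produces a large change in this assay: 4-cyanobenzyl in place of 3-methoxyphenoxy gives a 14-fold lower number from compound 3 to compound 4 (1.14 log units; beyond the scatter), and 4-cyanobenzyl in place of 2-methoxyphenoxy gives a 14-fold lower number from compound 1 to compound 4 (1.14 log units; beyond the scatter), whereas moving the methoxy group round the phenoxy ring gave no change at the digits printed from compound 1 to compound 3 (within the scatter). With 4-cyanobenzyl on that carbon, the group on the saturated chain carbon bound to an amine nitrogen makes no difference that can be read: furan-2-yl in place of 5-fluoro-2-methoxyphenyl gives no change at the digits printed from compound 2 to compound 4 (within the scatter). Nothing available offers an explanation for these numbers.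

The swap alters the link to the core and the ring substituent at once, so a plain benzyl or a 4-cyanophenoxy group on that carbon would be needed to separate the two. Going by these compounds, whether furan-2-yl and 5-fluoro-2-methoxyphenyl also read alike with a methoxyphenoxy group on that carbon remains open.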